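The source may hold more compounds than are shown below. What is called first, only, known or untested is meant among the compounds shown, and "the series" means these compounds.

Measured so far in a physicochemical assay for lipophilicity; on this read-out lower numbers stand for lower lipophilicity and higher numbers for higher lipophilicity:
- compound 1 `COc1ccc(C2=NO[C@]3(C2)C(=O)O[C@@H]2[C@H]3CC[C@H](C)[C@]3(O)C=CC(=O)[C@@]23C)cc1`: 1.47
- compound 2 `C[C@H]1CC[C@@H]2[C@@H](OC(=O)[C@]23CC(c2ccccc2Br)=NO3)[C@]2(C)C(=O)C=C[C@@]12O`: 2.22
- compound 3 `COc1cc(C2=NO[C@]3(C2)C(=O)O[C@@H]2[C@H]3CC[C@H](C)[C@]3(O)C=CC(=O)[C@@]23C)ccc1O`: 0.75

Compound 2 holds the highest of the three numbers. The nearest value is that of compound 1, and the furthest is that of compound 3.

Next in the series is compound 4 `C[C@H]1CC[C@@H]2[C@@H](OC(=O)[C@]23CC(c2ccccc2F)=NO3)[C@]2(C)C(=O)C=C[C@@]12O`, which differs from compound 2 by fluoro in place of bromo on an aromatic carbon. In words, this is fluoro in place of bromo on an aromatic carbon, ortho to a large group.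

Among the measured compounds shown here, no measured step exchanges bromo for fluoro, so direct evidence is lacking. The closest evidence comes from the three steps that change the same aryl group. These are the modest a number 0.75 log units higher from compound 1 to compound 2 (beyond the scatter), the large a number 1.47 log units lower from compound 2 to compound 3 (beyond the scatter) and the modest a number 0.72 log units lower from compound 1 to compound 3 (beyond the scatter). The two steps involving compound 2 both leave it as the higher compound, and neither retains bromo on the other side.

A downward move of modest size is therefore expected in this assay, smaller than the step to compound 3. The estimated step is a number 0.57 log units lower from compound 2 to compound 4 (beyond the scatter), probably beyond the scatter, although the upper end of the range is not.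

For compound 4 the estimated value is 1.65, with an expected range from 1.25 to 2.05.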

Compound 4, partition coefficient: 1.58
For compound 4 the middle estimate is 0.07 log units above the measured one; low and high end bracket the measured number.
By their numbers in this assay, from the lowest: compound 3; then compounds 1 and 4 (each within the scatter of the next); then compound 2.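

In this assay, among the compounds shown here, fluoro in place of bromo on an aromatic carbon, ortho to a large group, gives the only step that changes a single halogen atom and nothing else on the aryl group (a number 0.64 log units lower from compound 2 to compound 4 (beyond the scatter)). The 2-fluorophenyl group is not separated from the 4-methoxyphenyl group on this read-out (a number 0.11 log units higher from compound 1 to compound 4 (within the scatter)), yet it remains clearly apart from the 4-hydroxy-3-methoxyphenyl group (a number 0.83 log units higher from compound 3 to compound 4 (beyond the scatter)), so at this position compound 2 alone stands apart at the upper end, and the presence of a halogen does not by itself place a compound there, as compound 4 shows. No measurement among the data shown accounts for the size of these steps.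

The compounds shown leave open where chloro or an unsubstituted phenyl would fall in this assay, and whether the bromo-to-fluoro step keeps its size with the halogen on another ring carbon. As far as these compounds go, how a phenyl carrying an amine or a carboxylic acid would read at this position also stays open.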